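This account rests on a few compounds, and the source may have more. Where it says the series, first, only, none or still open, it means among the compounds named here.

Compound 1 `Clc1ncnc2c1ncn2Cc1ccccc1` and compound 2 `Fc1ccc(Cn2cnc3c(Cl)ncnc32)cc1` share one core, and compound 3 `CSc1ccc(-c2nc3c(Sc4ccccc4)ncnc3n2C)cc1` carries a second core; how the two cores differ is not broken down here. In an assay on isolated protein for inhibition of RAC-alpha serine/threonine-protein kinase (Homo sapiens), tested at 30 uM (on this read-out lower numbers stand for less inhibition and higher numbers for more inhibition at the one concentration tested (going by the name of the read-out)), compound 1 gives 0%, compound 2 gives 0%, and compound 3 gives 5%. Compound 2 arises from compound 1 through fluoro in place of hydrogen on an aromatic carbon and the step is no change at the digits printed from compound 1 to compound 2 (within the scatter). Compound 4 `CSc1ccc(-c2nc3c(Sc4ccc(F)cc4)ncnc3n2C)cc1` is not yet measured; it arises from compound 3 through (fluoro in place of hydrogen on an aromatic carbon), the same change, at the same kind of place. The writer expects a step of no change at the digits printed from compound 3 to compound 4 (within the scatter) in this assay, because no change at the digits printed from compound 1 to compound 2 (within the scatter) shows the change leaving the read-out where it was. The expectation also rests on the starting point, as compound 3 gives 5%, a low number on this read-out. Compound 4 is therefore estimated at 5%, between 0% and 15%.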

Compound 4, a percentage reported as inhibition, at one concentration (the size of the read-out at that concentration, not a potency): 0%
Compound 4: the middle estimate sits 5 percentage points above what was measured; the range from low to high includes it.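

In this assay, fluoro in place of hydrogen gives a number 5 percentage points lower from compound 3 to compound 4 (within the scatter), and set beside the earlier step, the change reads alike on the two cores: the same change on two cores in this assay, no change at the digits printed (within the scatter) from compound 1 to compound 2 and a number 5 percentage points lower (within the scatter) from compound 3 to compound 4, 5 percentage points apart, within the scatter of two such steps This shows that, for these two pairs, the change carries from one core to the other without a difference that can be read. Among these compounds, it does not show that the change would be equally silent on a compound with clear inhibition, as all four numbers lie low on this read-out and the two pairs cover only two cores.

The compounds shown leave open whether another group at this place, such as an amine or a carboxylic acid, would lift the read-out. They also leave open what replacing the methylsulfanyl group of compound 3 with a longer chain would do.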